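Iodobenzyl Added to a Bicyclic Adenosine Core

The source may hold more compounds than are shown below. What is called first, only, known or untested is meant among the compounds shown, and "the series" means these compounds.

Compound 1, `Nc1ncnc2c1ncn2[C@@H]1O[C@@]2(CO)CO[C@@H]1[C@@H]2O`: > 100000 nM
Compound 2, `CNC(=O)[C@@]12CO[C@@H]([C@H](n3cnc4c(N)ncnc43)O1)[C@@H]2O`: > 100000 nM

Of the compounds shown here, two have been measured in a functional assay for antagonist activity at adenosine receptor A3 (Homo sapiens), with a stated time of 30 min; a lower number here means a stronger inhibitor, a higher number a weaker inhibitor. Compound 1 `Nc1ncnc2c1ncn2[C@@H]1O[C@@]2(CO)CO[C@@H]1[C@@H]2O` gives > 100000 nM in this assay, a limit of the assay rather than a number. Compound 2 `CNC(=O)[C@@]12CO[C@@H]([C@H](n3cnc4c(N)ncnc43)O1)[C@@H]2O` gives > 100000 nM, again only a limit. The step between them is a step that the two limits leave unreadable from compound 1 to compound 2, unreadable because of the limit of > 100000 nM in this assay, at which 2 of the 2 values shown sit. Compound 2 thus stands only at that limit, with no number of its own.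

Compound 3 `CNC(=O)[C@@]12CO[C@@H]([C@H](n3cnc4c(NCc5cccc(I)c5)ncnc43)O1)[C@@H]2O` differs from compound 2 by 3-iodobenzyl in place of hydrogen on a nitrogen on an aromatic ring. Among the compounds with values here, no measured step touches the amine on the aromatic ring, and the only measured step, a step that the two limits leave unreadable from compound 1 to compound 2, gives neither size nor direction. The expectation for compound 3 therefore rests on the structural change alone and is loose: compound 3 is expected to give 10000 nM, within 500 nM to 100000 nM. That expected step, an at least 10-fold lower number from compound 2 to compound 3 (1.00 log units; beyond the scatter), means a move toward stronger inhibition from the limit.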

Compound 3, half-maximal inhibitory concentration: > 100000 nM
Compound 3: only a limit was reported; the forecaster's own chance of this, stated with the estimate: 30%; middle value at least 10-fold (1.00 log units) from the limit.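

In this assay compound 3 gives > 100000 nM which is again a limit of the assay and not a number. No step from compound 2 to compound 3 can be read: the limit of > 100000 nM in this assay, at which 3 of the 3 values shown sit.

The compounds shown leave open what 3-iodobenzyl on this nitrogen does to inhibition, with no compound here holding a number of its own.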